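This account rests on a few compounds, and the source may have more. Where it says the series, first, only, none or still open, it means among the compounds named here.

Series notes, values in a functional assay on SK-MEL-28 cells (Homo sapiens) for cytotoxicity, read by MTT assay; a lower number here means a stronger inhibitor, a higher number a weaker inhibitor:
compound 1 `O=C(NCCNc1nccc(-c2c(-c3cccc(F)c3)nc3sccn23)n1)c1c(F)cccc1F`: 11400 nM
compound 2 `O=C(NCCNc1nccc(-c2c(-c3cccc(F)c3)nc3sccn23)n1)c1ccc(C(F)(F)F)cc1`: 9260 nM
compound 3 `Cc1ccc(S(=O)(=O)NCCCNc2nccc(-c3c(-c4cccc(F)c4)nc4sccn34)n2)cc1`: 9500 nM

Compound 3 stands second among the three numbers; its nearest neighbour is compound 2 and its furthest is compound 1, and both gaps lie within the scatter. The next compound, compound 4 `Cc1ccc(C(=O)NCCNc2nccc(-c3c(-c4cccc(F)c4)nc4sccn34)n2)cc1`, differs from compound 3 by ((4-methylphenyl)carbonyl)amino in place of (((4-methylphenyl)sulfonyl)amino)methyl on a saturated chain carbon, two bonds along the chain from a nitrogen on an aromatic ring. Within the data shown here, two measured steps bear on this change: a 1.2-fold lower number from compound 1 to compound 2 (0.09 log units; within the scatter), a swap of the aryl on the carbonyl, and a 1.2-fold lower number from compound 1 to compound 3 (0.08 log units; within the scatter), which exchanges the amide arm for the sulfonamide arm. Neither step moved the number beyond the scatter, so on these three compounds neither the kind of arm nor the aryl on it has shifted the read-out. For compound 4, which returns to the amide arm of compounds 1 and 2 carrying a 4-methylphenyl group, no step beyond the scatter is expected in this assay; the expected step of no change at the digits printed from compound 3 to compound 4 (within the scatter) is essentially flat. The estimate for compound 4 is 9500 nM, with a range from 4000 nM to 22000 nM.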

Compound 4, half-maximal inhibitory concentration: 18800 nM
Compound 4: the middle estimate sits 2.0-fold (0.30 log units) below what was measured; low and high end bracket the measured number.
By their numbers in this assay, from the lowest: compounds 2, 3, 1 and 4 (each within the scatter of the next, the first and the last beyond it).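

In this assay, among these compounds, the swap of trifluoromethyl for methyl on an aromatic carbon of the amide arm gives a 2.0-fold higher number from compound 2 to compound 4 (0.31 log units; beyond the scatter), so this pair is the first to show a substituent on that aryl moving the read-out past the scatter, if only modestly. The other two steps, a 2.0-fold higher number from compound 3 to compound 4 (0.30 log units; within the scatter) for the change of arm and a 1.6-fold higher number from compound 1 to compound 4 (0.22 log units; within the scatter) for 4-methylphenyl in place of 2,6-difluorophenyl on the carbonyl carbon, stay within the scatter and separate neither arm nor aryl. No measurement here accounts for the step from trifluoromethyl to methyl.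

Open, on these data alone, is whether a chlorine, a methoxy or an amine on that aromatic carbon would extend or break this single modest step. Also open, as far as these compounds go, is whether an amide arm with a longer chain would shift the read-out at all.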